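The source may hold more compounds than are shown below. What is called first, only, known or untested is meant among the compounds shown, and "the series" means these compounds.

Measured in a functional assay on HCT-116 cells (Homo sapiens) for inhibition, read by CCK-8 assay, with a stated time of 48 h; on this read-out lower numbers stand for stronger inhibition and higher numbers for weaker inhibition:
- compound 1 `COc1ccc(CN(C(=O)CSC(=S)N2CCN(C(C)=O)CC2)c2cc(OC)c(OC)c(OC)c2)cc1`: 1370 nM
- compound 2 `COc1ccc(CN(C(=O)CSC(=S)N2CCc3cc(Br)ccc32)c2cc(OC)c(OC)c(OC)c2)cc1`: 8060 nM
- compound 3 `COc1ccc(CN(C(=O)CSC(=S)N2CCCc3cc(C)ccc32)c2cc(OC)c(OC)c(OC)c2)cc1`: 5230 nM

Compound 1 gives the lowest number of the three, and the steps to both others lie beyond the scatter. Compound 4 `COc1ccc(CN(C(=O)CSC(=S)N2CCCc3cc(OC)ccc32)c2cc(OC)c(OC)c(OC)c2)cc1` is still unmeasured. Its change from compound 1 is 6-methoxy-1,2,3,4-tetrahydroquinolin-1-yl in place of 4-acetylpiperazin-1-yl on a thiocarbonyl carbon.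

For the measured compounds named here, the closest precedent is a 3.8-fold higher number from compound 1 to compound 3 (0.58 log units; beyond the scatter), where 6-methyl-1,2,3,4-tetrahydroquinolin-1-yl enters. The step of a 5.9-fold higher number from compound 1 to compound 2 (0.77 log units; beyond the scatter), with 5-bromo-2,3-dihydro-1H-indol-1-yl entering, points the same way. The step of a 1.5-fold lower number from compound 2 to compound 3 (0.19 log units; within the scatter) lies within the scatter, so these two replacements are not separated. Going by the values given here, no measured compound carries the methoxy group, so its own contribution is unknown. A modest step to a higher number is therefore expected in this assay, close in size to the step to compound 3 with its 5230 nM. The estimated step is a 3.5-fold higher number from compound 1 to compound 4 (0.54 log units; beyond the scatter). For compound 4 the estimated value is 4800 nM, with an expected range of 2000 nM to 11000 nM.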

Compound 4, half-maximal inhibitory concentration: > 20000 nM
Compound 4 gave a limit, no number (the forecaster's own chance of this, stated with the estimate: 3%); middle value at least 4.1-fold (0.61 log units) away from the limit.
By their numbers in this assay, from the lowest: compound 1; then compounds 3 and 2 (each within the scatter of the next). At a limit, above all of these: compound 4.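

In this assay compound 4 gives > 20000 nM, which is a limit and not a number. The group on the aromatic carbon of the 1,2,3,4-tetrahydroquinolin-1-yl unit now separates compounds, with methoxy in place of methyl: an at least 3.8-fold higher number from compound 3 to compound 4 (0.58 log units; beyond the scatter). For the compounds shown here, the group on the thiocarbonyl carbon therefore spans a wider range than the earlier steps showed, with an at least 14-fold higher number from compound 1 to compound 4 (1.16 log units; beyond the scatter) and an at least 2.4-fold higher number from compound 2 to compound 4 (0.39 log units; beyond the scatter), and 4-acetylpiperazin-1-yl remains the only group here giving the lowest number.

As far as these compounds go, the true size of these steps stays unknown, since all three are bounds set by the limit. Also open, from the compounds shown here alone, is whether a chloro or hydroxy group on that aromatic carbon falls nearer compound 3 or compound 4, and whether a free amine on the piperazine in place of acetyl goes below compound 1.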